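This account rests on a few compounds, and the source may have more. Where it says the series, first, only, none or still open, it means among the compounds named here.

Among the measured compounds shown here, in a functional assay on LNCaP cells (Homo sapiens) for cytotoxicity, read by MTT assay (on this read-out lower numbers stand for stronger inhibition and higher numbers for weaker inhibition), compound 2 `COc1ccc(CSc2nnc([C@@H](C)c3ccc4cc(OC)ccc4c3)n2-c2ccc(F)cc2)cc1` gives 22800 nM, the only actual number so far. Compound 1 `COc1ccc2cc([C@H](C)c3nnc(SCc4ccc(C)cc4)n3-c3ccc(F)cc3)ccc2c1` is reported only as a limit, <= 400000 nM. Placing methoxy in place of methyl on an aromatic carbon is a step that the limit leaves unreadable from compound 1 to compound 2, due to the limit of <= 400000 nM in this assay, at which 1 of the 2 values shown sits. That single step offers no size to carry forward.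

Compound 3 `COc1ccc2cc([C@H](C)c3nnc(SCc4c(C)cc(C)cc4C)n3-c3ccc(F)cc3)ccc2c1` carries 2,4,6-trimethylphenyl in place of 4-methoxyphenyl on a saturated chain carbon bound to a sulfur. For the measured compounds named here, no measured step covers this exchange, so no direction can be argued, and no shift beyond the scatter is expected in this assay. The estimated change is a 1.0-fold lower number from compound 2 to compound 3 (0.02 log units; within the scatter). Going by the values given here, compound 3 is expected at 22000 nM, with an estimated range of 6000 nM to 80000 nM, kept wide because only one number supports it.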

Compound 3, half-maximal inhibitory concentration: 2210 nM
For compound 3 the middle estimate is 10-fold (1.00 log units) above the measured one; measured number below the stated range.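

Within this assay the group held on a saturated chain carbon bound to a sulfur clearly matters: 2,4,6-trimethylphenyl in place of 4-methoxyphenyl gives a 10-fold lower number from compound 2 to compound 3 (1.01 log units; beyond the scatter). Among the compounds shown here, this is the first readable size for a change at this place, and it lies beyond the scatter even though both groups hold one six-membered aromatic ring of carbon only. The steps that start from compound 1 still cannot be read, due to a single value that is a limit and not a number: the limit of <= 400000 nM in this assay, at which 1 of the 3 values shown sits.

As far as these compounds go, whether a simpler group such as 2,6-dimethylphenyl would keep the lower number remains open. Also open, from the compounds shown here alone, is how a phenyl ring carrying an amine or a carboxylic acid would read at this place.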